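Aryl change on the amide-type nitrogen: compound 4

The source may report more compounds than this note shows. Statements on the series, on what has been measured and on what is new or still open speak of the compounds shown alone.

Measured so far:
compound 1 `Cc1ccccc1NC(=O)Nc1cccc(CNc2ncnc3ccccc23)c1` — a functional assay on A549 cells (Homo sapiens) for antiproliferative activity, read by MTT assay (a higher number here means a weaker inhibitor, a lower number a stronger inhibitor), 40200 nM
compound 2 `O=C(Nc1cccc(CNc2ncnc3ccccc23)c1)Nc1ccccc1Cl` — this assay 18000 nM
compound 3 `O=C(Nc1cccc(Cl)c1)Nc1cccc(CNc2ncnc3ccccc23)c1` — this assay gives only a limit, > 50000 nM

Among the two numbers, compound 1 stands highest; the nearest is compound 2, with a 2.2-fold lower number from compound 1 to compound 2 (0.35 log units; beyond the scatter). The limit of compound 3 is the limit of > 50000 nM in this assay, at which 1 of the 3 values shown sits. Compound 4 `O=C(Nc1cccc(CNc2ncnc3ccccc23)c1)Nc1cccc(C(F)(F)F)c1` differs from compound 1 by 3-(trifluoromethyl)phenyl in place of 2-methylphenyl on an amide-type nitrogen. Among the compounds with values here, two steps bear on this change: an at least 1.2-fold higher number from compound 1 to compound 3 (0.09 log units; that floor lies within the scatter), the same placement on the amide-type nitrogen, and an at least 2.7-fold higher number from compound 2 to compound 3 (0.44 log units; beyond the scatter). Both point toward a higher number or a limit for the 3-substituted phenyl. Compound 4 is therefore expected to move by a 1.6-fold higher number from compound 1 to compound 4 (0.21 log units; within the scatter), quite possibly reaching the limit. The estimated value for compound 4 is 65000 nM, within 25000 nM to 170000 nM.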

Compound 4, half-maximal inhibitory concentration: 44200 nM
Beside the measured number, compound 4's estimate is 1.5-fold (0.17 log units) above it; the range from low to high includes it.
By their numbers in this assay, from the lowest: compound 2; then compounds 1 and 4 (each within the scatter of the next). At a limit, above all of these: compound 3.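

Compound 3 gives only a limit, > 50000 nM, in this assay. Trifluoromethyl in place of chloro on an aromatic carbon gives an at least 1.1-fold lower number from compound 3 to compound 4 (0.05 log units; that floor lies within the scatter). With 3-(trifluoromethyl)phenyl in place of 2-methylphenyl on the amide-type nitrogen, this series now has a measured number for a 3-substituted phenyl, and the step is a 1.1-fold higher number from compound 1 to compound 4 (0.04 log units; within the scatter). The 2-chlorophenyl group remains apart, with a 2.5-fold higher number from compound 2 to compound 4 (0.39 log units; beyond the scatter).

Left open is how an amine or a carboxylic acid on this phenyl ring would read. Also open, on these data alone, is whether trifluoromethyl in place of the chloro of compound 2 would keep that lower number.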